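The source may report more compounds than this note shows. Statements on the series, on what has been measured and on what is new or still open speak of the compounds shown alone.

Working notes on the series in an assay on membranes from liver for displacement of a labelled ligand from Sigma intracellular receptor 2 (Rattus norvegicus), read by scintillation counting, with a stated time of 120 min; a lower number here means a stronger inhibitor, a higher number a weaker inhibitor.

Compound 1 `CN(CCCc1ccccc1)C1CCc2ccccc2C(O)C1` gives 35 nM. Compound 2 `OC1Cc2ccccc2CCC1NCCCc1ccccc1` gives 100 nM. Compound 3 `OC1CC(NCCCc2ccccc2)CCc2ccccc21` gives 28 nM, the lowest number of the three; the gap to compound 1 lies within the scatter, the gap to compound 2 beyond it. For the measured compounds named here, the only single-place step measured is a 1.3-fold lower number from compound 1 to compound 3 (0.10 log units; within the scatter), and it bears only on the amine nitrogen, not on the ring bearing the hydroxy group. Going by the values given here, compound 2 and compound 3 differ in more than one place, so their two values show only that the arrangement of compound 3 gives the lower number.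

Compound 4 `OC1c2ccccc2CCC(NCCCc2ccccc2)C1O` is obtained from compound 3 by hydroxy in place of hydrogen on a saturated ring carbon. Among the compounds with values here, no measured step in this assay covers a second hydroxy on the saturated ring, so the expectation rests on the absence of large steps elsewhere. The expected step is a 1.6-fold higher number from compound 3 to compound 4 (0.21 log units; within the scatter), not beyond the scatter in either direction, with a wide range. Compound 4 is therefore estimated at 45 nM, between 15 nM and 150 nM.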

Compound 4, inhibition constant: 630 nM
Compound 4: the middle estimate sits 14-fold (1.15 log units) below what was measured; the whole stated range lies below it.
By their numbers in this assay, from the lowest: compounds 3 and 1 (each within the scatter of the next); then compound 2; then compound 4.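

In this assay, for the compounds shown here, the entering hydroxy on a saturated ring carbon of the seven-membered non-aromatic ring gives the only large single-place step, with a 23-fold higher number from compound 3 to compound 4 (1.35 log units; beyond the scatter) at a carbon next to the ring atom that bears a hydroxy group and next to the ring atom that bears a large group. The same diol is reached with a 6.3-fold higher number from compound 2 to compound 4 (0.80 log units; beyond the scatter) as well, so both compounds carrying one hydroxy give a higher number on taking up the second, a modest step from compound 2 and a large one from compound 3. The compounds shown offer no measurement that accounts for either step.

Still open, on these data alone, is whether a methoxy or a fluorine at this carbon would give a similar step or whether it is confined to hydroxy. Also open, as far as these compounds go, is whether a methyl on the amine nitrogen of compound 4 would change its number as little as it does between compound 1 and compound 3.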